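An Ester Swap Tested for Cytotoxicity on HeLa Cells

The source may hold more compounds than are shown below. What is called first, only, known or untested is meant among the compounds shown, and "the series" means these compounds.

Measured compounds:
compound 1 `CCCC(O)CC(=O)O[C@H](CC=C(C)C)C1=CC(=O)c2c(O)ccc(O)c2C1=O`: 59300 nM
compound 2 `CCCC(CC(=O)O[C@H](CC=C(C)C)C1=CC(=O)c2c(O)ccc(O)c2C1=O)OC(C)=O`: 51200 nM

In a functional assay on HeLa cells (Homo sapiens) for cytotoxicity, read by MTT assay (a higher number here means a weaker inhibitor, a lower number a stronger inhibitor), compound 1 gives 59300 nM and compound 2 gives 51200 nM. Within the data shown here, of these two numbers compound 2 holds the lower one, but the only step between them, a 1.2-fold lower number from compound 1 to compound 2 (0.06 log units; within the scatter), lies within the scatter, so the two compounds are not separated. Compound 3 `CC(C)=CC[C@@H](OC(=O)C1CCCO1)C1=CC(=O)c2c(O)ccc(O)c2C1=O` differs from compound 2 at the ester: oxolan-2-yl in place of 2-acetoxypentyl on a carbonyl carbon. Among the measured compounds shown here, no measured step covers an exchange of this kind; the single step known, a 1.2-fold lower number from compound 1 to compound 2 (0.06 log units; within the scatter), altered only the acetyl on the chain and stayed within the scatter. With nothing in the data pointing either way, compound 3 is expected to stay close to compound 2, the step of a 1.0-fold lower number from compound 2 to compound 3 (0.01 log units; within the scatter) being within the scatter. Compound 3 is therefore estimated at 50000 nM, with a range from 18000 nM to 140000 nM.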

Compound 3, half-maximal inhibitory concentration: 17000 nM
For compound 3 the middle estimate is 2.9-fold (0.47 log units) above the measured one; the whole stated range lies above it.
By their numbers in this assay, from the lowest: compound 3; then compounds 2 and 1 (each within the scatter of the next).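

In this assay the group on the carbonyl carbon of the ester proves to be a place where the number moves, which the acetyl on the chain did not show: oxolan-2-yl in place of 2-acetoxypentyl gives a 3.0-fold lower number from compound 2 to compound 3 (0.48 log units; beyond the scatter) and oxolan-2-yl in place of 2-hydroxypentyl gives a 3.5-fold lower number from compound 1 to compound 3 (0.54 log units; beyond the scatter) as the second step of the same kind. Among these compounds, both steps are modest but beyond the scatter, so compound 3 holds the lowest number of the three and is the first compound here to separate from the others. Nothing available here accounts for this drop.

Oxolan-2-yl differs from the chains both in having a ring and in its count of heavy atoms, so the compounds shown do not tell these two features apart. As far as these compounds go, whether cyclopentyl, which lacks the ring oxygen, or an open butyl chain would match compound 3 remains open.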